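Swapping 3,4-dichlorophenyl for 3-methoxyphenyl on a shared core

The source may report more compounds than this note shows. Statements on the series, on what has been measured and on what is new or still open speak of the compounds shown alone.

Of the compounds shown here, two have numbers so far in a functional assay on B16-F10 cells (Mus musculus) for antiproliferative activity, read by MTT assay, with a stated time of 48 h; on this read-out lower numbers stand for stronger inhibition and higher numbers for weaker inhibition. Compound 1 `CCCCCCCCCCCCOc1ccc(C(=O)/C=C/c2c(/C=C/c3ccc(OC)cc3)cc(OC)cc2OC)cc1` gives 12.7 ug/mL, and compound 2 `COc1ccc(/C=C/c2cc(OC)cc(OC)c2/C=C/C(=O)c2ccc(Cl)c(Cl)c2)cc1` gives 7.5 ug/mL. These two values lie within the usual scatter of each other, so compound 2 stands level with compound 1 on the numbers shown. Compound 3 `COc1ccc(/C=C/c2cc(OC)cc(OC)c2/C=C/C(=O)c2cccc(OC)c2)cc1` keeps the core of compound 2 and carries 3-methoxyphenyl in place of 3,4-dichlorophenyl on a carbonyl carbon. Going by the values given here, no measured pair differs in one place only, so the data hold no direct guide to this change. The values of compound 1 at 12.7 ug/mL and compound 2 at 7.5 ug/mL still suggest a narrow span for this family. The expected step of a 1.3-fold higher number from compound 2 to compound 3 (0.12 log units; within the scatter) is therefore none beyond the scatter. For compound 3 the estimated value is 10 ug/mL, with an expected range of 4.5 ug/mL to 22 ug/mL.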

Compound 3, half-maximal inhibitory concentration: 4.3 ug/mL
Compound 3: the middle estimate sits 2.3-fold (0.37 log units) above what was measured; the measured number lies below the stated range.
By their numbers in this assay, from the lowest: compounds 3, 2 and 1 (each within the scatter of the next, the first and the last beyond it).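

In this assay, going by these compounds alone, replacing 3,4-dichlorophenyl with 3-methoxyphenyl on a carbonyl carbon gives a 1.7-fold lower number from compound 2 to compound 3 (0.24 log units; within the scatter), and this is the first direct reading of any single change. At this position, on the core shared by compound 2 and compound 3, the two chlorine atoms can therefore give way to a methoxy group without a change that stands clear of the scatter, so the two compounds read as level. Nothing shown explains why these two groups read alike.

Going by these compounds, whether this position would tolerate an amine, a carboxylic acid or a longer chain on the same ring remains open. Also open, on these data alone, is whether the same exchange would read alike on a different core, since this single pair speaks only for the core of compound 2.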